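Dropping a Chloro Group from a Compound Already at the Limit

This account rests on a few compounds, and the source may have more. Where it says the series, first, only, none or still open, it means among the compounds named here.

Compound 1 `CC(=O)Nc1ccc2nc(SCC(=O)NCc3ccccc3)sc2c1`: 9200 nM
Compound 2 `CC(=O)Nc1ccc2nc(SCC(=O)NCc3ccc(Cl)cc3)sc2c1`: 6700 nM
Compound 3 `O=C(CSc1nc2ccc(NC(=O)c3ccc([N+](=O)[O-])cc3)cc2s1)NCc1ccc(Cl)cc1`: > 100000 nM (a limit of the assay, not a number)

All three were tested in a functional assay on HepG2 cells (Homo sapiens) for cytotoxicity, read by MTT assay, with a stated time of 48 h; on this read-out higher numbers stand for weaker inhibition and lower numbers for stronger inhibition. Compound 1 and compound 2 share a core and differ only in the change (hydrogen in place of chloro on an aromatic carbon). That change gave a 1.4-fold higher number from compound 2 to compound 1 (0.14 log units; within the scatter), so the two values cannot be told apart.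

Compound 3 carries the chloro of compound 2 but differs in its core by the change (4-nitrophenyl in place of methyl on a carbonyl carbon). That change gave an at least 14-fold higher number from compound 2 to compound 3 (1.17 log units; beyond the scatter). For compound 3 this assay reports only a limit, namely (the limit of > 100000 nM in this assay, at which 1 of the 3 values shown sits).

Compound 4 `O=C(CSc1nc2ccc(NC(=O)c3ccc([N+](=O)[O-])cc3)cc2s1)NCc1ccccc1` is still unmeasured. It differs from compound 3 by hydrogen in place of chloro on an aromatic carbon, which is the same change that takes compound 2 to compound 1; both changes sit on an aromatic carbon of a six-membered aromatic ring of carbon only, para to a large group. Since the same change between compound 2 and compound 1 stayed within the scatter a 1.4-fold higher number from compound 2 to compound 1 (0.14 log units; within the scatter), compound 4 is expected to sit where compound 3 sits, and the expected step is a step that the limit leaves unreadable from compound 3 to compound 4. Compound 4 is therefore estimated at 150000 nM in this assay , most likely again reported only as a limit, with a range from 50000 nM to 500000 nM.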

Compound 4, half-maximal inhibitory concentration: > 100000 nM
Compound 4: only a limit was reported (the forecaster's own chance of this, stated with the estimate: 85%); the middle value lies beyond the limit too.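

In this assay, 4-nitrophenyl in place of methyl on a carbonyl carbon has now been seen without the chloro as well as with it, and without it the change gave an at least 10-fold higher number from compound 1 to compound 4 (1.03 log units; beyond the scatter), so in these two pairs the number rises in the same direction whether the benzyl group carries chloro or hydrogen. Whether the rise has the same size on both cores cannot be settled: the same change on two cores in this assay, an at least 14-fold higher number (1.17 log units; beyond the scatter) from compound 2 to compound 3 and an at least 10-fold higher number (1.03 log units; beyond the scatter) from compound 1 to compound 4; the limit leaves it open whether they differ

The step between compound 3 and compound 4 cannot be read, so these data do not show whether hydrogen in place of chloro matters once the 4-nitrophenyl group is present, and two pairs are too few to make a rule for the series: the limit of > 100000 nM in this assay, at which 2 of the 4 values shown sit.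

The compounds shown leave open how the numbers behave between the two extremes, for instance with a plain phenyl, an ethyl or a longer chain on that carbonyl carbon. They also leave open whether the nitro group or the phenyl ring itself goes with the rise, a question that a phenyl ring carrying an amine or a carboxylic acid in place of the nitro group could start to answer.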